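A 3-fluorophenyl group at an assay limit

The source may report more compounds than this note shows. Statements on the series, on what has been measured and on what is new or still open speak of the compounds shown alone.

In a functional assay on ECa-109 cells for inhibition, with ECa-109 cell line (Homo sapiens) as the target, read by sulforhodamine B assay (on this read-out lower numbers stand for stronger inhibition and higher numbers for weaker inhibition), compound 1 `O=C1C(NC2CCCC2)=CC(=O)c2c1nc1n2[C@H]2OC[C@@H](O)[C@H]2OC1` reads > 16000 nM as a limit and not a number. Compound 2 `O=C1C(N2CCCC2)=CC(=O)c2c1nc1n2[C@H]2OC[C@@H](O)[C@H]2OC1` reads > 16000 nM as a limit too. Compound 3 `CCOc1ccc(NC2=CC(=O)c3c(nc4n3[C@H]3OC[C@@H](O)[C@H]3OC4)C2=O)cc1` reads > 4000 nM as a limit as well, so it has no exact place among these compounds. The evidence consists only of the limit of > 16000 nM in this assay, at which 2 of the 3 values shown sit, and the limit of > 4000 nM in this assay, at which 1 of the 3 values shown sits, with no measured number in the group.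

Compound 4 `O=C1C(Nc2cccc(F)c2)=CC(=O)c2c1nc1n2[C@H]2OC[C@@H](O)[C@H]2OC1` carries 3-fluorophenyl in place of 4-ethoxyphenyl on an amine nitrogen. The closest measured change is a step that the two limits leave unreadable from compound 1 to compound 3 on that same nitrogen. A less direct one is a step that the two limits leave unreadable from compound 1 to compound 2 on a double-bonded ring carbon. Neither has a readable size, so neither sets a direction, and no shift beyond the scatter is expected.

The estimated change is a step that the limit leaves unreadable from compound 3 to compound 4 in this assay with that uncertainty attached. The estimate for compound 4 is 8000 nM with an expected range from 2500 nM to 25000 nM and another limit remains the likeliest report.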

Compound 4, half-maximal inhibitory concentration: 2370 nM
Estimate against measurement, compound 4: 3.4-fold (0.53 log units) above; the whole stated range lies above it.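

For the compounds shown here, compound 4 is the first compound here to give a number rather than a limit in this assay, so a group on this amine nitrogen now has a measured reading. With 3-fluorophenyl on that nitrogen, the data show an at least 6.7-fold lower number from compound 1 to compound 4 (0.82 log units; beyond the scatter) and an at least 6.7-fold lower number from compound 2 to compound 4 (0.82 log units; beyond the scatter), whereas the change from 4-ethoxyphenyl gives an at least 1.6-fold lower number from compound 3 to compound 4 (0.22 log units; that floor lies within the scatter), so the exchange of one aryl group for the other is not shown to matter beyond the scatter. The first two steps are floors, because compound 1 and compound 2 sit at a limit: the limit of > 16000 nM in this assay, at which 2 of the 4 values shown sit.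

On these data alone, how far compound 4 truly lies from compound 3 stays open. As far as these compounds go, whether a plain phenyl, a chlorophenyl or a methoxyphenyl on that nitrogen would read like 3-fluorophenyl also stays open.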